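Ring contraction of a hydroxylated amide in a stable series

The compounds below may be only part of what the source reports. "The series", "measured", "known", "first", "only" and "open" are said of these compounds alone.

Of the compounds shown here, two of one series have been measured in an ADME assay on microsomes from liver (Mus musculus) for metabolic stability, read by LC-MS, using NADPH, with a stated time of 30 min, tested at 0.1 uM, in the presence of a further agent that is not named here; a higher number here means that more of the compound is left, a lower number that less of the compound is left. Compound 1 `CS(=O)(=O)c1ccc(-c2cnc(N)c(-c3ccc(N)nc3)n2)cc1` returns a value that is a limit of the assay, > 90%. Compound 2 `Nc1ncc(-c2ccc(C(=O)N3CCC(O)CC3)cc2)nc1-c1ccc(C(F)(F)F)cc1` likewise returns only a limit, > 90%. Among the measured compounds shown here, compound 2 therefore stands at the top of what this assay reports, and it shares that position with the only other value shown: the limit of > 90% in this assay, at which 2 of the 2 values shown sit. For the measured compounds named here, no step between measured compounds is available to size the effect of any change.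

The account now turns to compound 3 `Nc1ncc(-c2ccc(C(=O)N3CCC(O)C3)cc2)nc1-c1ccc(C(F)(F)F)cc1`, which differs from compound 2 in one place: 3-hydroxypyrrolidin-1-yl in place of 4-hydroxypiperidin-1-yl on a carbonyl carbon. Both measured compounds sit at the limit, so compound 3 is expected to show a step from compound 2 that is none beyond the scatter, a number no higher from compound 2 to compound 3 (the limit leaves the size open). Compound 3 is expected to give about 90%, within 80% to 95%.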

Compound 3, percent of the compound remaining: > 90%
Compound 3 gave a limit, no number (the forecaster's own chance of this, stated with the estimate: 70%); the middle value sits exactly at the limit.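

No new step can be read from compound 2 to compound 3, since both return only limits in this assay: the limit of > 90% in this assay, at which 3 of the 3 values shown sit.

The compounds shown leave open how much of each remains, and so whether 3-hydroxypyrrolidin-1-yl in place of 4-hydroxypiperidin-1-yl changes the read-out at all.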